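Naphthyl in Place of Pyrrolylphenyl on the Anilide Nitrogen

The source may hold more compounds than are shown below. What is called first, only, known or untested is meant among the compounds shown, and "the series" means these compounds.

Compound 2 `C[C@H](NC(=O)C(=O)Nc1ccccc1-c1ccc[nH]1)C(=O)N[C@@H](CC(=O)O)C(=O)COc1c(F)c(F)cc(F)c1F` carries a 1H-pyrrol-2-yl on an aromatic carbon of compound 1 `C[C@H](NC(=O)C(=O)Nc1ccccc1)C(=O)N[C@@H](CC(=O)O)C(=O)COc1c(F)c(F)cc(F)c1F`. In a functional assay on Jurkat cells (Homo sapiens) for inhibition (on this read-out lower numbers stand for stronger inhibition and higher numbers for weaker inhibition), compound 1 gives 670 nM and compound 2 gives 56 nM, so compound 2 stands as the lower of the two numbers, and the step of a 12-fold lower number from compound 1 to compound 2 (1.08 log units; beyond the scatter) is large. Compound 3 `C[C@H](NC(=O)C(=O)Nc1cccc2ccccc12)C(=O)N[C@@H](CC(=O)O)C(=O)COc1c(F)c(F)cc(F)c1F` differs from compound 2 in one place: naphthalen-1-yl in place of 2-(1H-pyrrol-2-yl)phenyl on an amide-type nitrogen. Within the data shown here, the only measured step that bears on this is the one from compound 1 to compound 2, which shows that a second aromatic ring at this position lowers the number strongly; compound 3 also carries two aromatic rings there, but the hydrogen-bond donor of the pyrrole leaves. The number for compound 3 in this assay is therefore expected to rise modestly, a step of a 2.7-fold higher number from compound 2 to compound 3 (0.43 log units; beyond the scatter). Compound 3 is estimated at 150 nM, with a range from 50 nM to 500 nM.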

Compound 3, half-maximal inhibitory concentration: 86 nM
For compound 3 the middle estimate is 1.7-fold (0.24 log units) above the measured one; the range from low to high includes it.
By their numbers in this assay, from the lowest: compounds 2 and 3 (each within the scatter of the next); then compound 1.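

In this assay, naphthalen-1-yl in place of 2-(1H-pyrrol-2-yl)phenyl on the amide-type nitrogen gives a 1.5-fold higher number from compound 2 to compound 3 (0.19 log units; within the scatter), so the two groups cannot be told apart on this read-out, although the pyrrole and its hydrogen-bond donor have left. Against the plain phenyl of compound 1, the same naphthalen-1-yl gives a 7.8-fold lower number from compound 1 to compound 3 (0.89 log units; beyond the scatter), which shows that the gain at this position does not need the pyrrole nitrogen and can also come with two six-membered aromatic rings of carbon only. No independent measurement is available to explain why these two groups read alike.

Still open, on these data alone, is whether the second ring has to be aromatic at all, as a piperidine or morpholine in place of the pyrrole would show. A carboxylic acid or an amine there could likewise show whether a smaller group can do the same.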